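The source may report more compounds than this note shows. Statements on the series, on what has been measured and on what is new or still open speak of the compounds shown alone.

Compound 2, `C/N=C(\S)NCCCCCn1nc(-c2ccccc2)ccc1=O`, gives 68.9% in a functional assay on the whole organism with Rattus norvegicus as the target, at a dose of 100 mg/kg (a lower number here means less inhibition, a higher number more inhibition at the dose given (going by the name of the read-out)), the highest of the three numbers recorded. Compound 1, `O=c1ccc(-c2ccccc2)nn1CCCCNC(=S)Nc1ccc(Cl)cc1`, gives 43.2% in this assay, and compound 3, `C/N=C(/NC#N)NCCCCCn1nc(C)ccc1=O`, gives 14.9%; both sit below compound 2 by more than the scatter. Compound 4, `C/N=C(\S)NCCCCCCn1nc(-c2ccccc2)ccc1=O`, has not yet been measured. It differs from compound 2 by a group of 6 heavy atoms (3 carbon, 2 nitrogen, 1 sulfur; no ring) in place of a group of 5 heavy atoms (2 carbon, 2 nitrogen, 1 sulfur; no ring), on a saturated chain carbon, five bonds along the chain from an aromatic nitrogen. Within the data shown here, no step of this kind between measured compounds is available, so its effect is unknown; a shift of this size is expected to stay within the scatter in this assay, in either direction. Compound 4 is therefore estimated at 62% in this assay, with a range from 40% to 82%. The expected step is a number 6.9 percentage points lower from compound 2 to compound 4 (within the scatter), with no direction claimed beyond the scatter.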

Compound 4, a percentage reported as inhibition, in the whole organism at one dose (the size of the read-out at that dose, not a potency): 22.2%
Compound 4: the middle estimate sits 39.8 percentage points above what was measured; measured number below the stated range.
By their numbers in this assay, from the lowest: compounds 3 and 4 (each within the scatter of the next); then compound 1; then compound 2.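

In this assay, this place proves highly sensitive: a group of 6 heavy atoms in place of a group of 5 heavy atoms gives a number 46.7 percentage points lower from compound 2 to compound 4 (beyond the scatter). Among these compounds, this is the only step here between compounds that differ in one place, so it is the sole direct evidence that so small a change can matter at this position. Nothing available accounts for the loss. Going by these compounds, whether a still longer chain at this place would give a similar number remains open. So does how an amine there would compare.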